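The compounds below may be only part of what the source reports. "The series", "measured", "known", "first", "only" and "open" are said of these compounds alone.

Working notes on the series. In a functional assay on MCF7 cells (Homo sapiens) for inhibition, read by MTT assay, with a stated time of 48 h, tested at 7.5 ug/mL (on this read-out higher numbers stand for more inhibition of growth at the one concentration tested and lower numbers for less inhibition of growth), compound 1 `Cc1cc(C)c2c(c1)CN(c1ccc3c(=O)cc(-c4ccccc4)oc3c1)CO2` gives 11.3%. Compound 2 `O=c1cc(-c2ccccc2)oc2ccc(N3COc4c(Br)cc(Br)cc4C3)cc12`, the other measured member of the series, gives 6.54% in this assay; the two numbers lie within the scatter of each other, so the data do not separate compound 1 from compound 2. Both show weak inhibition of growth at the concentration tested.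

Compound 3 `Cc1cccc2c1OCN(c1ccc3c(=O)cc(-c4ccccc4)oc3c1)C2` is not yet measured. It differs from compound 1 by hydrogen in place of methyl on an aromatic carbon. Among the compounds with values here, no measured pair of the series isolates such a change, so there is no recorded step to lean on. A single methyl removed from the shared core, with the rest of compound 1 unchanged, is expected to leave the read-out essentially where it is: the step from compound 1 to compound 3 is estimated at a number 2.3 percentage points lower from compound 1 to compound 3 (within the scatter), that is, none beyond the scatter. Compound 3 is accordingly estimated to give 9% in this assay, with a range from 0% to 20%.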

Compound 3, percent growth inhibition at one concentration: 43.9%
Estimate against measurement, compound 3: 34.9 percentage points below; the measured number lies above the stated range.
By their numbers in this assay, from the lowest: compounds 2 and 1 (each within the scatter of the next); then compound 3.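

Hydrogen in place of methyl on an aromatic carbon, para to a fused ring and meta to a methyl group, gives a number 32.6 percentage points higher from compound 1 to compound 3 (beyond the scatter) in this assay. This single position therefore has a large bearing on the read-out, and the loss of one methyl is enough to produce the change. The earlier compounds offered no step at any single position, and nothing available here bears on what lies behind this one.

The compounds shown leave open whether the higher number belongs to hydrogen itself or would persist with another group on this carbon, such as fluorine, methoxy or an amine. On these data alone, how the read-out responds to hydrogen in place of the other methyl of compound 1 also remains open.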